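Swapping a pyrazole for a methylsulfanyl group on the phenyl ring

A few compounds are considered here, and "the series" means these few. Any claim that something is new, unique, unknown or untested is made for them only; others in the source may bear on it.

Measured so far:
- compound 1, `COc1cccc(NC(=O)c2nnn(Cc3cc(C)on3)c2N)c1`: 174000 nM
- compound 2, `COc1cccc(NC(=O)c2nnn(Cc3ccc(-n4cccn4)cc3)c2N)c1`: 20000 nM

Both compounds were tested in a physicochemical assay for solubility, read by nephelometry, at pH 7.4; on this read-out higher numbers stand for higher solubility and lower numbers for lower solubility. Compound 1 gives 174000 nM, and compound 2 gives 20000 nM, the lower of the two numbers, with a gap between them that lies beyond the usual scatter. The next compound, compound 3 with the structure `COc1cccc(NC(=O)c2nnn(Cc3ccc(SC)cc3)c2N)c1`, differs from compound 2 in one place: methylsulfanyl in place of 1H-pyrazol-1-yl on an aromatic carbon.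

For the measured compounds named here, no step between measured compounds isolates the effect of this kind of change, so the expectation rests only on the two values at hand. The group that enters is small and has no ring, the group that leaves is a five-membered aromatic ring; the data give no direct guide to how this alters the read-out. Compound 3 is estimated at 15000 nM, within a range of 5000 nM to 60000 nM, which means an expected step of a 1.3-fold lower number from compound 2 to compound 3 (0.12 log units; within the scatter), a change that may not rise beyond the scatter.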

Compound 3, solubility: < 12000 nM
Compound 3: no number, only a limit; the forecaster's own chance of this, stated with the estimate: 10%; middle value at least 1.2-fold (0.09 log units) from the limit.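

Compound 3 has no number in this assay, only a limit of the assay: the limit of < 12000 nM in this assay, at which 1 of the 3 values shown sits.

Even so, this is the first look at this position, and exchanging the five-membered aromatic ring of 1H-pyrazol-1-yl for methylsulfanyl, which has no ring, gives an at least 1.6-fold lower number from compound 2 to compound 3 (0.22 log units; that floor lies within the scatter), so this swap brings no gain on this read-out and any loss remains unproven. The wider change, 4-(methylsulfanyl)phenyl in place of 5-methyl-1,2-oxazol-3-yl, gives an at least 14-fold lower number from compound 1 to compound 3 (1.16 log units; beyond the scatter), a large drop even at its smallest possible size.

As far as these compounds go, how far the true value of compound 3 lies past its limit remains open, and with it the true size of both steps. Also open, from the compounds shown here alone, is how an amine or a carboxylic acid on this same aromatic carbon would read in this assay.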